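The compounds below may be only part of what the source reports. "The series", "measured", "known", "first", "only" and "open" are said of these compounds alone.

Among the compounds with values here, in an ADME assay on S9 fraction from liver (Rattus norvegicus) for metabolic stability, read by LC-MS, using NADPH, with a stated time of 60 min, tested at 10 uM (a higher number here means that more of the compound is left, a lower number that less of the compound is left), compound 1 `C[C@H](O)Cc1cc(-c2ccnc3[nH]nc(C(F)(F)F)c23)cc(C2(C#N)CC2)c1` gives 37%, the lower of the two numbers measured so far. The other number belongs to compound 2 `N#CC1(c2cc(CC(O)C(F)(F)F)cc(-c3ccnc4[nH]nc(C(F)(F)F)c34)c2)CC1`, which gives 71%. Compound 3 `COCC(O)Cc1cc(-c2ccnc3[nH]nc(C(F)(F)F)c23)cc(C2(C#N)CC2)c1` has not yet been measured. It differs from compound 1 as follows: 1-hydroxy-2-methoxyethyl in place of 1-hydroxyethyl on a saturated chain carbon bound to an aromatic carbon. In words, 1-hydroxy-2-methoxyethyl stands in place of 1-hydroxyethyl on a saturated chain carbon bound to an aromatic carbon. Within the data shown here, only one measured step bears on this change: a number 34 percentage points higher from compound 1 to compound 2 (beyond the scatter). There, 2,2,2-trifluoro-1-hydroxyethyl replaced 1-hydroxyethyl at the same place, so the read-out in this assay is known to respond to a change there. Among the measured compounds shown here, the group entering compound 3 is a different one, however, and no measured compound carries it, so neither the size nor the direction of that step can simply be carried over. No step beyond the scatter is therefore expected, though with wide uncertainty on both sides. The estimated step is a number 1 percentage points higher from compound 1 to compound 3 (within the scatter). Compound 3 is expected to give 38%, with an estimated range from 20% to 58%.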

Compound 3, percent of the compound remaining: 51%
Beside the measured number, compound 3's estimate is 13 percentage points below it, within the range that was stated.
By their numbers in this assay, from the lowest: compound 1; then compound 3; then compound 2.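

In this assay, the place on a saturated chain carbon bound to an aromatic carbon now responds to a second, non-fluorinated group: 1-hydroxy-2-methoxyethyl in place of 1-hydroxyethyl gives a number 14 percentage points higher from compound 1 to compound 3 (beyond the scatter). The earlier rise therefore does not belong to 2,2,2-trifluoro-1-hydroxyethyl alone, although the two replacing groups are not equivalent, since methoxymethyl in place of trifluoromethyl on the saturated chain carbon bound to an oxygen gives a number 20 percentage points lower from compound 2 to compound 3 (beyond the scatter). Nothing in the data shown accounts for either step.

From the compounds shown here alone, it remains open how this assay would respond to an amine, a carboxylic acid or an ethoxymethyl group at this place, and so whether the order seen with these three compounds would extend to other groups. Also open is what the defined stereocentre contributes, as 1-hydroxyethyl carries one while the 1-hydroxy-2-methoxyethyl group is listed without one, and separate (R) and (S) forms of compound 3 would be needed to tell its share of the step from that of the methoxy group.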